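Working notes: methyl on the benzyl ring of compound 2

A few compounds are considered here, and "the series" means these few. Any claim that something is new, unique, unknown or untested is made for them only; others in the source may bear on it.

Among the measured compounds shown here, compound 2 `O=C(O)c1cccc(NC(=O)c2cccc(OCc3ccccc3)c2)c1`, measured in an assay on isolated protein for agonist activity at Bile acid receptor (Homo sapiens), read by TR-FRET, with a stated time of 3 h, in the absence of a further agent (on this read-out higher numbers stand for an effect only at larger amounts of compound and lower numbers for an effect already at smaller amounts), gives 1160 nM, the lowest of the two numbers so far. For the measured compounds named here, compound 1 `CCCCOc1cccc(C(=O)Nc2cccc(C(=O)O)c2)c1` gives 3150 nM in this assay, and the step of a 2.7-fold lower number from compound 1 to compound 2 (0.43 log units; beyond the scatter), phenyl in place of propyl, is the only measured step. Compound 3 `Cc1cccc(COc2cccc(C(=O)Nc3cccc(C(=O)O)c3)c2)c1` differs from compound 2 by methyl in place of hydrogen on an aromatic carbon, benzyloxy to (3-methylbenzyl)oxy. Going by the values given here, no measured step bears on a methyl added to this ring, so no change beyond the scatter is expected. Compound 3 is estimated at 950 nM, range 350 nM to 2600 nM, with an expected step of a 1.2-fold lower number from compound 2 to compound 3 (0.09 log units; within the scatter).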

Compound 3, half-maximal effective concentration: 1860 nM
Estimate against measurement, compound 3: 2.0-fold (0.29 log units) below; the measured number falls inside the stated range.
By their numbers in this assay, from the lowest: compounds 2, 3 and 1 (each within the scatter of the next, the first and the last beyond it).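

The step of a 1.6-fold higher number from compound 2 to compound 3 (0.21 log units; within the scatter) shows that methyl in place of hydrogen on this aromatic carbon of the benzyl ring is tolerated. The step of a 1.7-fold lower number from compound 1 to compound 3 (0.23 log units; within the scatter) places compound 3 within the scatter of compound 1 as well, although the step from compound 1 to compound 2 lay beyond it. Nothing available explains these steps.

Open, on these data alone, is whether a chlorine, a methoxy or an amine on this same carbon would move the number beyond the scatter, and whether any group on this ring gives a number lower than that of compound 2.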